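Replacing dichlorophenyl with dibromophenyl in a cytotoxicity series

The source may hold more compounds than are shown below. What is called first, only, known or untested is meant among the compounds shown, and "the series" means these compounds.

In a functional assay on C8166 cells (Homo sapiens) for cytotoxicity, read by MTT assay (on this read-out higher numbers stand for lower toxicity in this test and lower numbers for higher toxicity in this test), compound 1 (`Cc1cc(S(N)(=O)=O)ccc1NC(=O)COc1ccc(Cl)cc1NC(=O)c1ccccc1`) gives 207000 nM, compound 2 (`Cc1ccc(C(=O)Nc2cc(Cl)ccc2OCC(=O)Nc2ccc(S(N)(=O)=O)cc2C)cc1`) gives 54200 nM and compound 3 (`Cc1cc(S(N)(=O)=O)ccc1NC(=O)COc1ccc(Cl)cc1NC(=O)c1ccc(Cl)c(Cl)c1`) gives 158000 nM. Compound 3 thus stands with compound 1, apart from compound 2. Compound 4 (`Cc1cc(S(N)(=O)=O)ccc1NC(=O)COc1ccc(Cl)cc1NC(=O)c1cc(Br)cc(Br)c1`) has 3,5-dibromophenyl in place of 3,4-dichlorophenyl on a carbonyl carbon. Earlier changes to the group on that carbonyl carbon gave a 3.8-fold lower number from compound 1 to compound 2 (0.58 log units; beyond the scatter), a 1.3-fold lower number from compound 1 to compound 3 (0.12 log units; within the scatter) and a 2.9-fold higher number from compound 2 to compound 3 (0.46 log units; beyond the scatter). None of these steps was large, so no step beyond the scatter is expected in this assay, although a modest one in either direction remains possible. The expected change is a 1.1-fold lower number from compound 3 to compound 4 (0.05 log units; within the scatter). Compound 4 is estimated at 140000 nM, with an expected range of 60000 nM to 300000 nM.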

Compound 4, half-maximal cytotoxic concentration: 89700 nM
The estimate for compound 4 lay 1.6-fold (0.19 log units) above the measured number, within the range that was stated.
By their numbers in this assay, from the lowest: compounds 2, 4, 3 and 1 (each within the scatter of the next, the first and the last beyond it).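

In this assay, 3,5-dibromophenyl in place of 3,4-dichlorophenyl on the carbonyl carbon stays within the scatter (a 1.8-fold lower number from compound 3 to compound 4 (0.25 log units; within the scatter)). Compound 4 also lies within the scatter of the 4-methylphenyl compound (a 1.7-fold higher number from compound 2 to compound 4 (0.22 log units; within the scatter)), while its step from the phenyl compound lies beyond it (a 2.3-fold lower number from compound 1 to compound 4 (0.36 log units; beyond the scatter)). The earlier split, with compound 3 alongside compound 1 and apart from compound 2, therefore gives way to a continuous spread, with compound 4 linking compound 2 and compound 3.

The compounds shown do not separate the change of halogen from the change in ring positions, and how a carboxylic acid or an amine on this ring would read remains open. No measurement at hand bears on why these steps fall as they do.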